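Replacing the 2-nitrophenyl group of compound 3

The source may report more compounds than this note shows. Statements on the series, on what has been measured and on what is new or still open speak of the compounds shown alone.

In a functional assay on MCF7 cells (Homo sapiens) for cytotoxicity, read by MTT assay, with a stated time of 96 h (on this read-out lower numbers stand for stronger inhibition and higher numbers for weaker inhibition), compound 1 `COc1cc(C(=O)c2cn(-c3ccccc3)cc2-c2ccccc2C)cc(OC)c1OC` gives 190 nM, compound 2 `COc1cc(C(=O)c2cn(-c3ccccc3)cc2-c2ccccc2Br)cc(OC)c1OC` gives 190 nM and compound 3 `COc1cc(C(=O)c2cn(-c3ccccc3)cc2-c2ccccc2[N+](=O)[O-])cc(OC)c1OC` gives 49 nM, the lowest of the three numbers. Compound 4 `COc1ccc(-c2cn(-c3ccccc3)cc2C(=O)c2cc(OC)c(OC)c(OC)c2)cc1` carries 4-methoxyphenyl in place of the 2-nitrophenyl of compound 3: 4-methoxyphenyl in place of 2-nitrophenyl on an aromatic carbon. Three measured steps change this same aryl group. Two are modest, a 3.9-fold lower number from compound 1 to compound 3 (0.59 log units; beyond the scatter) and a 3.9-fold lower number from compound 2 to compound 3 (0.59 log units; beyond the scatter), while the third shows no change at the digits printed from compound 1 to compound 2 (within the scatter). None of them tests a 4-methoxyphenyl group, so they offer only a rough guide to size, and a small rise is the likeliest outcome. The expected change is a 1.4-fold higher number from compound 3 to compound 4 (0.15 log units; within the scatter). For compound 4 the estimated value is 70 nM, with an expected range from 18 nM to 270 nM.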

Compound 4, half-maximal inhibitory concentration: 70 nM
For compound 4 middle estimate and measured number coincide at the digits printed; low and high end bracket the measured number.
By their numbers in this assay, from the lowest: compounds 3 and 4 (each within the scatter of the next); then compounds 1 and 2 (each within the scatter of the next).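

Losing the nitro group does not cost the low number here: the 4-methoxyphenyl group holds level with 2-nitrophenyl (a 1.4-fold higher number from compound 3 to compound 4 (0.15 log units; within the scatter)). Compound 4 also improves on the other two aryl groups (a 2.7-fold lower number from compound 2 to compound 4 (0.43 log units; beyond the scatter); a 2.7-fold lower number from compound 1 to compound 4 (0.43 log units; beyond the scatter)), so at this position a nitro group is not the only route to a lower number than 2-bromophenyl or 2-methylphenyl give. Nothing measured here explains these differences.

Still open, from the compounds shown here alone, is whether the methoxy group itself matters or where it sits on the phenyl ring, which 2-methoxyphenyl would help to separate. Also open, going by these compounds, is how an amine or a carboxylic acid on this phenyl ring would compare.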